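The compounds below may be only part of what the source reports. "The series", "measured", "known", "first", "only" and "open" are said of these compounds alone.

Compound 1 `CCCCCCOc1c(-c2cc(OC)c(OC)c(OC)c2)oc2ccccc2c1=O`: 19600 nM
Compound 2 `CCC(C)Oc1c(-c2cc(OC)c(OC)c(OC)c2)oc2ccccc2c1=O`: 9300 nM

Both numbers come from a functional assay on LNCaP cells (Homo sapiens) for antiproliferative activity, read by WST assay, with a stated time of 3 days; on this read-out lower numbers stand for stronger inhibition and higher numbers for weaker inhibition. Of the two, compound 2 has the lower number, 9300 nM, so it is the stronger inhibitor of this pair. Compound 3 `CCCC(C)Oc1c(-c2cc(OC)c(OC)c(OC)c2)oc2ccccc2c1=O` has not yet been measured. Its structure differs from that of compound 2 by one small change: methyl in place of hydrogen on a saturated chain carbon, three bonds along the chain from an oxygen on an aromatic ring. Put another way, sec-butyl becomes 1-methylbutyl.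

Among the measured compounds shown here, only one measured step bears on this change: a 2.1-fold lower number from compound 1 to compound 2 (0.32 log units; beyond the scatter). That modest step came with sec-butyl in place of hexyl, so the longer hexyl chain carried the higher number. Two compounds cannot establish a trend, and no branched chain other than sec-butyl has been measured. Still, the change to compound 3 is smaller than the one separating hexyl from sec-butyl, so only a slight shift towards a higher number in this assay is expected, probably within the scatter. The expected step is a 1.3-fold higher number from compound 2 to compound 3 (0.11 log units; within the scatter). For compound 3, the estimated value is 12000 nM, with an expected range from 6000 nM to 24000 nM.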

Compound 3, half-maximal inhibitory concentration: 15100 nM
The estimate for compound 3 lay 1.3-fold (0.10 log units) below the measured number; measured number inside the range.
By their numbers in this assay, from the lowest: compounds 2, 3 and 1 (each within the scatter of the next, the first and the last beyond it).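

Extending sec-butyl to 1-methylbutyl adds a single methyl at the end of the branched chain and gives a 1.6-fold higher number from compound 2 to compound 3 (0.21 log units; within the scatter) in this assay, so at this position the added carbon does not move the number beyond the usual scatter. Compound 3 also stays close to the straight-chain compound, with a 1.3-fold lower number from compound 1 to compound 3 (0.11 log units; within the scatter), so 1-methylbutyl in place of hexyl does not separate the two either, and compound 3 cannot be told apart from compound 1 or compound 2, even though a 2.1-fold lower number from compound 1 to compound 2 (0.32 log units; beyond the scatter) lies beyond the scatter. No measurement offered here accounts for these small differences.

From the compounds shown here alone, with so few chains compared, it remains open whether a larger branched chain such as 1-methylpentyl or a ring such as cyclohexyl on the same oxygen would give a number clearly apart from these in this assay. Going by these compounds, it is equally open how a chain ending in an amine or a carboxylic acid would read in that place.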